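Removing the chloro from the benzyl amide of compound 1

This account rests on a few compounds, and the source may have more. Where it says the series, first, only, none or still open, it means among the compounds named here.

In a functional assay on MCF7 cells (Homo sapiens) for antiproliferative activity, read by sulforhodamine B assay, with a stated time of 48 h (a lower number here means a stronger inhibitor, a higher number a weaker inhibitor), compound 1 (`COc1ccc(C[C@@H](O)/C=C/C=C/C(=O)NCc2ccc(Cl)cc2)cc1OC`) gives 18100 nM and compound 2 (`COc1ccc(C[C@@H](O)/C=C/C=C/C(=O)N2CCN(C(c3ccccc3)c3ccccc3)CC2)cc1OC`) gives 12500 nM in the same read-out. These two numbers lie within the scatter of each other, so compound 1 cannot be separated from compound 2 on the data so far.

Compound 3 (`COc1ccc(C[C@@H](O)/C=C/C=C/C(=O)NCc2ccccc2)cc1OC`) has not yet been measured in this assay and keeps the core of compound 1. For the measured compounds named here, the only change is at the 4-chlorophenyl, which becomes phenyl, with hydrogen in place of chloro on an aromatic carbon, para to a large group: hydrogen in place of chloro on an aromatic carbon is the whole difference.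

Going by the values given here, no measured pair in this small set isolates this change, so the data offer no direct precedent for its size or direction. Taking compound 1 at 18100 nM as the anchor, no shift beyond the scatter is expected. The estimated move is a 1.2-fold higher number from compound 1 to compound 3 (0.06 log units; within the scatter) and is expected to stay within the scatter. For compound 3 the expected value is 21000 nM with an estimated range from 9500 nM to 46000 nM in this read-out.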

Compound 3, half-maximal inhibitory concentration: 33600 nM
Beside the measured number, compound 3's estimate is 1.6-fold (0.20 log units) below it; low and high end bracket the measured number.
By their numbers in this assay, from the lowest: compounds 2, 1 and 3 (each within the scatter of the next, the first and the last beyond it).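

In this assay, for the compounds shown here, this pair gives the first direct reading at this position: a 1.9-fold higher number from compound 1 to compound 3 (0.27 log units; within the scatter) and is the only step available for hydrogen in place of chloro on an aromatic carbon, para to a large group. The 4-chlorobenzyl of compound 1 and the benzyl of compound 3 therefore cannot be separated on these data, and the chloro is not shown to be needed for the activity seen in this read-out. Nothing at hand bears on the cause of this result, and one pair sets no rule for the wider series.

Still open, on these data alone, is whether an amine, a carboxylic acid or a nitrile on the same aromatic carbon would move the number beyond the scatter, in either direction, from the values of compound 1 and compound 3. Equally open, as far as these compounds go, is whether a longer chain in place of the single carbon linking the phenyl to the amide nitrogen would give a step that can be told apart from the scatter.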